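The source may report more compounds than this note shows. Statements on the series, on what has been measured and on what is new or still open speak of the compounds shown alone.

In a functional assay on SK-MEL-2 cells (Homo sapiens) for cytotoxicity (a lower number here means that less compound is needed, a higher number that more compound is needed for the effect), compound 1 `CCCCC/C=C\C[C@@H](O)[C@H](O)/C=C/[C@@H]1C/C=C\CCCC(=O)O1` gives 12.4 ug/mL, and compound 2 `CC/C=C\C/C=C\C[C@@H](O)[C@H](O)/C=C/[C@@H]1C/C=C\CCCC(=O)O1` gives 4.4 ug/mL. Going by the values given here, compound 2 thus holds the lower of the two numbers measured; the only measured step, a 2.8-fold lower number from compound 1 to compound 2 (0.45 log units; beyond the scatter), came with but-1-en-1-yl in place of butyl on a saturated chain carbon bound to a double-bonded chain carbon. Compound 3 `CC/C=C\C/C=C\C[C@H](O)[C@H](O)/C=C/[C@@H]1C/C=C\CCCC(=O)O1` differs from compound 2 by the two compounds have the same atoms and bonds and differ only in configuration as drawn: 1 of 7 stereo elements differ; a stereocentre at a saturated chain carbon is drawn R in compound 2 and S in compound 3. No measured step concerns a change of configuration, so nothing shown bears directly on it, and the expectation is a step of a 1.3-fold higher number from compound 2 to compound 3 (0.10 log units; within the scatter), within the scatter. Compound 3 is therefore estimated at 5.5 ug/mL, in a range from 2 ug/mL to 15 ug/mL.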

Compound 3, concentration for half-maximal effect: 4.9 ug/mL
Beside the measured number, compound 3's estimate is 1.1-fold (0.05 log units) above it; low and high end bracket the measured number.
By their numbers in this assay, from the lowest: compounds 2 and 3 (each within the scatter of the next); then compound 1.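

In this assay, the configuration of this saturated chain carbon has little bearing on the number: the change of the stereocentre from R to S gives a 1.1-fold higher number from compound 2 to compound 3 (0.05 log units; within the scatter). The earlier step concerned the chain rather than configuration, so this is the first reading on a stereocentre, and it is a clean comparison: the fact that compounds 2 and 3 differ only in the configuration as drawn

Going by these compounds, whether the other stereocentres are equally undemanding remains open. So does whether an amine or a methyl ether in place of the hydroxyl on this carbon would move the number.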